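A few compounds are considered here, and "the series" means these few. Any claim that something is new, unique, unknown or untested is made for them only; others in the source may bear on it.

Measured in an ADME assay on microsomes from liver (Homo sapiens) for metabolic stability, read by LC-MS, with a stated time of 40 min, tested at 0.5 uM; on this read-out lower numbers stand for slow clearance and higher numbers for fast clearance:

Compound 1 `O=C(Nc1cccc(S(=O)(=O)C2CCCC2)c1)c1cccnc1N1CCC(F)(F)CC1`: > 399 mL.min-1.g-1 (a limit of the assay)
Compound 2 `CC(C)S(=O)(=O)c1cccc(NC(=O)c2cccnc2N2CCC3(CC2)CC3)c1`: 375 mL.min-1.g-1

Within the data shown here, compound 2 holds the only true number in this pair. The reading for compound 1, > 399 mL.min-1.g-1, is only a limit.

Compound 3 `O=C(Nc1cccc(S(=O)(=O)NC2CC2)c1)c1cccnc1N1CCC2(CC1)CC2` keeps the core of compound 2 and carries cyclopropylamino in place of isopropyl on a sulfonyl sulfur. The same change reads isopropylsulfonyl to cyclopropylsulfamoyl. Among the measured compounds shown here, no measured pair differing in one place exists here, so its size in this assay can only be estimated. Compound 2, at 375 mL.min-1.g-1, leaves little room upward, so any visible change is more likely to be a fall. The expected change is modest, an estimated 1.6-fold lower number from compound 2 to compound 3 (0.21 log units; within the scatter), which stays within the usual scatter. Compound 3 is expected at 230 mL.min-1.g-1, with an estimated range of 100 mL.min-1.g-1 to 399 mL.min-1.g-1.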

Compound 3, intrinsic clearance in microsomes: > 399 mL.min-1.g-1
Compound 3 was reported as a limit; the forecaster's own chance of this, stated with the estimate: 15%; middle value at least 1.7-fold (0.23 log units) from the limit.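

Compound 3 is reported only as a limit, not as a number. In this assay, putting cyclopropylamino in place of isopropyl on a sulfonyl sulfur gives an at least 1.0-fold higher number from compound 2 to compound 3 (0.02 log units; that floor lies within the scatter), so this change, which brings in a three-membered ring and a hydrogen-bond donor, does not move the reading towards slow clearance. The true size of the step cannot be read, because the reading stops at a limit: the limit of > 399 mL.min-1.g-1 in this assay, at which 2 of the 3 values shown sit.

As far as these compounds go, how far compound 3 lies past that limit remains open, as does what the same change would do on another core. Also open, from the compounds shown here alone, is whether methyl on the sulfonyl sulfur, or a group there carrying an amine or a carboxylic acid, would give a clearly lower number in this assay.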